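Dichlorophenyl for dimethoxyphenyl on the sulfonamide-linked benzylamine

The compounds below may be only part of what the source reports. "The series", "measured", "known", "first", "only" and "open" are said of these compounds alone.

Working notes on the series. Three compounds have numbers in a functional assay on MIA PaCa-2 cells (Homo sapiens) for inhibition, read by MTT assay, with a stated time of 72 h; a lower number here means a stronger inhibitor of growth, a higher number a weaker inhibitor of growth. Compound 2 `COc1ccc(CNCCCNS(=O)(=O)c2cc(C(F)(F)F)cc(C(F)(F)F)c2)cc1OC` gives 2800 nM, the lowest of the three; compound 3 `O=S(=O)(NCCCCCCNCc1ccc(Br)cc1)c1ccccc1F` gives 13300 nM and compound 1 `CC(C)(C)c1ccc(CNCCNS(=O)(=O)c2cc(C(F)(F)F)cc(C(F)(F)F)c2)cc1` gives 15000 nM, both standing above compound 2 by more than the scatter. Compound 4 `O=S(=O)(NCCCNCc1ccc(Cl)c(Cl)c1)c1cc(C(F)(F)F)cc(C(F)(F)F)c1` keeps the core of compound 2 and changes one place: 3,4-dichlorophenyl in place of 3,4-dimethoxyphenyl on a saturated chain carbon bound to an amine nitrogen. Within the data shown here, no measured pair shows this change on its own, and compounds 1 and 3 differ from compound 2 in more than this one place, so no step can be borrowed from them. The expected step of a 1.3-fold higher number from compound 2 to compound 4 (0.10 log units; within the scatter) is small, near the scatter, leaning toward a slightly higher number. Compound 4 is therefore estimated at 3500 nM, within a range from 1000 nM to 12000 nM.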

Compound 4, concentration for 50% growth inhibition: 2700 nM
Compound 4: the middle estimate sits 1.3-fold (0.11 log units) above what was measured, within the range that was stated.
By their numbers in this assay, from the lowest: compounds 4 and 2 (each within the scatter of the next); then compounds 3 and 1 (each within the scatter of the next).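

In this assay, this position gets its first single-change reading, a 1.0-fold lower number from compound 2 to compound 4 (0.02 log units; within the scatter), so 3,4-dichlorophenyl and 3,4-dimethoxyphenyl cannot be told apart on this chain. In this pair, growth inhibition therefore does not depend on the hydrogen-bond acceptors counted on 3,4-dimethoxyphenyl, which 3,4-dichlorophenyl lacks. No measurement at hand accounts for this match.

Going by these compounds, whether a phenyl ring carrying a carboxylic acid or an amine would fit this place remains open. On these data alone, it is also open whether the match would hold on a longer chain.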